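A Methyl Added Beside a Pyridine Amide at the Limit

The source may hold more compounds than are shown below. What is called first, only, known or untested is meant among the compounds shown, and "the series" means these compounds.

Of the compounds shown here, three built on one shared core have been tested in an ADME assay on HepG2 cells (Homo sapiens) for inhibition, with a stated time of 72 h; a lower number here means that less compound is needed, a higher number that more compound is needed for the effect. Compound 1 `C=C(C)C(=O)Nc1cccc(-c2nc3ccccc3s2)c1` sits at > 25000 nM, which is a limit of the assay and not a number. Compound 2 `O=C(CCl)Nc1cccc(-c2nc3ccccc3s2)c1` gives 16000 nM. Compound 3 `O=C(Nc1cccc(-c2nc3ccccc3s2)c1)c1cnccc1Cl` likewise returns only the limit of > 25000 nM. This holds for most of the series: the limit of > 25000 nM in this assay, at which 2 of the 3 values shown sit. The step of an at least 1.5-fold higher number from compound 2 to compound 3 (0.19 log units; that floor lies within the scatter) exchanged the group on the carbonyl carbon, while a step that the two limits leave unreadable from compound 1 to compound 3 cannot be read. Compound 4 `Cc1ccc(-c2nc3ccccc3s2)cc1NC(=O)c1cnccc1Cl` differs from compound 3 by methyl in place of hydrogen on an aromatic carbon. Among the measured compounds shown here, none of the measured steps touches this position, so the change is expected to leave the number within the scatter, a step that the limit leaves unreadable from compound 3 to compound 4. Compound 4 is therefore estimated at 40000 nM, within the range 8000 nM to 200000 nM.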

Compound 4, half-maximal effective concentration: > 25000 nM
Compound 4 ended at the assay's limit (the forecaster's own chance of this, stated with the estimate: 75%); the middle value lies beyond the limit too.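

Compound 3 and compound 4 both return a limit of the assay and not a number, so no step between them can be read: the limit of > 25000 nM in this assay, at which 3 of the 4 values shown sit.

The compounds shown leave open whether methyl in place of hydrogen shifts the number in this assay.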